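Bulk on the amide nitrogen in a thiophene-methyl series

A few compounds are considered here, and "the series" means these few. Any claim that something is new, unique, unknown or untested is made for them only; others in the source may bear on it.

Within the data shown here, compound 3 `Cc1ccc(OCC(=O)N(Cc2cccs2)C(C)(C)C)cc1` gives 11000 nM in an assay on HEK293 cells for agonist activity at transient receptor potential cation channel subfamily M member 8 (Homo sapiens), read by fluorescence and calcium flux, with a stated time of 15 min (a higher number here means that more compound is needed for the effect, a lower number that less compound is needed), the highest of the three numbers so far. Compound 1 `CCN(Cc1cccs1)C(=O)COc1ccc(C)cc1` gives 8 nM and compound 2 `CCC(C)N(Cc1cccs1)C(=O)COc1ccc(C)cc1` gives 2000 nM in this assay. The measured steps all concern the group on the amide-type nitrogen: a 250-fold higher number from compound 1 to compound 2 (2.40 log units; beyond the scatter), a 1400-fold higher number from compound 1 to compound 3 (3.14 log units; beyond the scatter) and a 5.5-fold higher number from compound 2 to compound 3 (0.74 log units; beyond the scatter), each beyond the scatter and each in the upward direction as that group grows. Compound 4 `Cc1ccc(OCC(=O)N(Cc2cccs2)c2nccn2C)cc1` carries 1-methyl-1H-imidazol-2-yl in place of tert-butyl on an amide-type nitrogen. Among the measured compounds shown here, no measured step covers a ring at this place, so the precedent is indirect; the expectation is for a step of a 2.2-fold lower number from compound 3 to compound 4 (0.34 log units; beyond the scatter) in this assay, with wide uncertainty. Compound 4 is estimated at 5000 nM, in the range 500 nM to 50000 nM.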

Compound 4, half-maximal effective concentration: 1790 nM
Compound 4: the middle estimate sits 2.8-fold (0.45 log units) above what was measured; the range from low to high includes it.
By their numbers in this assay, from the lowest: compound 1; then compounds 4 and 2 (each within the scatter of the next); then compound 3.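

On the amide-type nitrogen, the number no longer simply rises with the size of the group: 1-methyl-1H-imidazol-2-yl has more heavy atoms than tert-butyl yet gives a 6.1-fold lower number from compound 3 to compound 4 (0.79 log units; beyond the scatter) in this assay. It also gives a 1.1-fold lower number from compound 2 to compound 4 (0.05 log units; within the scatter) and so matches sec-butyl, but it stays far from ethyl with a 220-fold higher number from compound 1 to compound 4 (2.35 log units; beyond the scatter) and does not recover the number of the smallest group. Nothing at hand explains these steps.

On these data alone, whether the ring itself or its nitrogen atoms carry the step stays open, and a phenyl ring at this place would bear on that. As far as these compounds go, how a methyl group there compares with ethyl also stays open.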